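Methyl in place of hydrogen on the ethoxy group

A few compounds are considered here, and "the series" means these few. Any claim that something is new, unique, unknown or untested is made for them only; others in the source may bear on it.

Of the compounds shown here, two sharing one core have been measured in a functional assay on Vas deferens for antagonist activity at Alpha-1A adrenergic receptor (Rattus norvegicus); a higher number here means a more potent compound, by a factor of ten per unit of this negative logarithm, a lower number a less potent compound. Compound 1 `COc1cccc(OC)c1OCCNCCOc1ccccc1OCc1cccc(C)c1` gives 8.3, and compound 2 `CCOc1ccc(COc2ccccc2OCCNCCOc2c(OC)cccc2OC)cc1` gives 8.5. Compound 2 thus holds the highest of the two numbers, with compound 1 as its nearest neighbour; the step of a number 0.20 log units higher from compound 1 to compound 2 (within the scatter) lies within the scatter, so the two are indistinguishable here.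

Compound 3 `COc1cccc(OC)c1OCCNCCOc1ccccc1OCc1ccc(OC(C)C)cc1` is not yet measured. It differs from compound 2 by methyl in place of hydrogen on a saturated chain carbon bound to an oxygen on an aromatic ring and a saturated chain carbon. For the measured compounds named here, the only measured step that bears on this change is the one from compound 1 to compound 2, which also altered the group on that saturated chain carbon, and it was a number 0.20 log units higher from compound 1 to compound 2 (within the scatter), a step within the scatter. On that basis the addition of a single methyl is expected to give a step of no change at the digits printed from compound 2 to compound 3 (within the scatter) in this assay, that is, no change beyond the scatter in either direction. Compound 3 is therefore estimated at 8.5, with a range from 7.9 to 9.1.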

Compound 3, negative logarithm of the antagonist equilibrium constant: 8.17
For compound 3 the middle estimate is 0.33 log units above the measured one; measured number inside the range.
By their numbers in this assay, from the lowest: compounds 3, 1 and 2 (each within the scatter of the next, the first and the last beyond it).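

In this assay, for the compounds shown here, going from ethoxy to isopropoxy is the first change to move the number beyond the scatter, giving a number 0.33 log units lower from compound 2 to compound 3 (beyond the scatter), a modest step from a single methyl on a saturated chain carbon bound to an oxygen on an aromatic ring and a saturated chain carbon. Replacing 3-methylphenyl with 4-isopropoxyphenyl gives a number 0.13 log units lower from compound 1 to compound 3 (within the scatter), so this wider exchange of the group cannot be told from no change, while the one added methyl can. Nothing available explains why the added methyl lowers the number.

The compounds shown leave open whether the trend continues with tert-butoxy in place of isopropoxy, or whether it reverses with a longer straight chain such as n-propoxy. They also leave open how 4-methoxyphenyl or 4-hydroxyphenyl would stand against 4-ethoxyphenyl, and so whether ethoxy sits at a peak or merely on a slope at this position.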